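Removing a Chain Methyl from a Receptor Agonist

This account rests on a few compounds, and the source may have more. Where it says the series, first, only, none or still open, it means among the compounds named here.

Of the compounds shown here, two with a shared core have been tested in a functional assay on HEK293 cells for agonist activity at G-protein coupled receptor 84 (Homo sapiens), read by calcium flux; on this read-out lower numbers stand for an effect already at smaller amounts and higher numbers for an effect only at larger amounts of compound. Compound 2 `CCCCCCCC(C)c1nc(O)cc(O)n1` gives 299 nM. Compound 1 `CCCCCCc1nc(O)cc(O)n1` gives 454 nM in this assay, a gap from compound 2 that lies within the usual scatter, so the two stand together. Compound 3 `CCCCCCCCc1nc(O)cc(O)n1` differs from compound 2 by hydrogen in place of methyl on a saturated chain carbon bound to an aromatic carbon and a saturated chain carbon. Within the data shown here, no measured pair shows this change, so its size is open; with the two known values this close, no step beyond the scatter in either direction is expected. Compound 3 is estimated at 260 nM in this assay, with a range of 110 nM to 650 nM. The expected step of a 1.2-fold lower number from compound 2 to compound 3 (0.06 log units; within the scatter) is accordingly small.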

Compound 3, half-maximal effective concentration: 11.4 nM
Beside the measured number, compound 3's estimate is 23-fold (1.36 log units) above it; the whole stated range lies above it.
By their numbers in this assay, from the lowest: compound 3; then compounds 2 and 1 (each within the scatter of the next).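

Replacing the methyl on this chain carbon with hydrogen brings a 26-fold lower number from compound 2 to compound 3 (1.42 log units; beyond the scatter) in this assay and so reveals a sensitivity at this position that the close values of the two earlier compounds did not show. Ethyl in place of hydrogen on a saturated chain carbon, six bonds along the chain from an aromatic carbon, brings a 40-fold lower number from compound 1 to compound 3 (1.60 log units; beyond the scatter) in this assay as well, so chain length also counts when this carbon carries no methyl. Going by these compounds, whether a longer chain would lower the number further, and whether an ethyl or a hydroxyl on the methyl-bearing carbon would match methyl, stays open. Nothing at hand explains the size of these steps.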